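The source may hold more compounds than are shown below. What is called first, only, known or untested is meant among the compounds shown, and "the series" means these compounds.

Values measured so far in a functional assay on MOLT-4 cells (Homo sapiens) for inhibition, read by MTT assay, with a stated time of 72 h (on this read-out higher numbers stand for weaker inhibition and lower numbers for stronger inhibition), are these:

compound 1 `COc1cc(NC(C)CCCNC(=O)Nc2cccc(F)c2)c2ncccc2c1` gives 23000 nM
compound 2 `COc1cc(NC(C)CCCNC(=O)NNC(=O)Nc2ccc(Br)cc2)c2ncccc2c1` gives 209000 nM
compound 3 `COc1cc(NC(C)CCCNC(=O)Nc2cc(C(F)(F)F)cc(C(F)(F)F)c2)c2ncccc2c1` gives 12000 nM

Compound 2 has the highest number of the three, so it shows the weakest inhibition in this small set. Compound 4 `COc1cc(NC(C)CCCNC(=O)NNC(=O)Nc2cccc(Cl)c2)c2ncccc2c1` has not yet been measured. It keeps all of compound 2 except for one change, 3-chlorophenyl in place of 4-bromophenyl on an amide-type nitrogen, counted as 3-chlorophenyl in place of 4-bromophenyl on an amide-type nitrogen in full.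

Going by the values given here, only one measured step bears on this change, and only indirectly. That step, a 9.1-fold higher number from compound 1 to compound 2 (0.96 log units; beyond the scatter) for the whole swap, is modest in size, and it replaces a larger piece than the one changing here. It therefore says nothing about this exchange of phenyl groups alone. The values of compound 1 at 23000 nM and compound 3 at 12000 nM lie within the usual scatter of each other, but two values set no rule.

The closest guide is compound 2 at 209000 nM as a starting point, so no change beyond the scatter is expected. The expected step is a 1.4-fold lower number from compound 2 to compound 4 (0.14 log units; within the scatter) in this assay and should be small. For compound 4 the estimated value is 150000 nM with an expected range from 50000 nM to 350000 nM in this read-out.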

Compound 4, half-maximal inhibitory concentration: 93000 nM
Compound 4: the middle estimate sits 1.6-fold (0.21 log units) above what was measured, within the range that was stated.
By their numbers in this assay, from the lowest: compounds 3 and 1 (each within the scatter of the next); then compound 4; then compound 2.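

In this assay, the change from 4-bromophenyl to 3-chlorophenyl on the amide-type nitrogen gives a 2.2-fold lower number from compound 2 to compound 4 (0.35 log units; beyond the scatter), the first sign that the phenyl group at the end of this longer piece affects the read-out, although only modestly. The longer piece still carries a cost with the new phenyl group, with a 4.0-fold higher number from compound 1 to compound 4 (0.61 log units; beyond the scatter) when ((3-chlorophenyl)carbamoyl)amino replaces 3-fluorophenyl, so 3-chlorophenyl narrows the gap to compound 1 without closing it. No independent measurement accompanies these values to explain the shift, so the reason for it remains unknown.

Since 4-bromophenyl and 3-chlorophenyl differ in both the halogen and where it sits, these compounds cannot show which of the two matters, and 4-chlorophenyl or 3-bromophenyl at the same place would separate them. Going by these compounds, it also remains open how an unsubstituted phenyl or a 3,5-bis(trifluoromethyl)phenyl would behave at the end of the longer piece, and whether the number would then come closer to those of compound 1 and compound 3.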